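Swapping methyl for cyano on the sulfonyl-bearing ring

The source may report more compounds than this note shows. Statements on the series, on what has been measured and on what is new or still open speak of the compounds shown alone.

Measured compounds:
Compound 1, `O=C1/C(=C/c2ccccc2F)CN(S(=O)(=O)c2ccc(C(F)(F)F)cc2)C/C1=C\c1ccccc1F`, gives 4900 nM.
Compound 2, `CC(=O)Nc1ccc(S(=O)(=O)N2C/C(=C\c3ccccc3F)C(=O)/C(=C/c3ccccc3F)C2)cc1`, gives 5200 nM.
Compound 3, `Cc1ccc(S(=O)(=O)N2C/C(=C\c3cccc(F)c3)C(=O)/C(=C/c3cccc(F)c3)C2)cc1`, gives 3500 nM.

All three were tested in a functional assay on HepG2 cells (Homo sapiens) for cytotoxicity, read by MTT assay, with a stated time of 24 h; on this read-out higher numbers stand for weaker inhibition and lower numbers for stronger inhibition. Compound 3 has the lowest of the three numbers, but its gaps to compound 1 and to compound 2 both lie within the scatter, so no order among the three can be claimed. Compound 4, `N#Cc1ccc(S(=O)(=O)N2C/C(=C\c3cccc(F)c3)C(=O)/C(=C/c3cccc(F)c3)C2)cc1`, has not been measured yet. It differs from compound 3 in one place: cyano in place of methyl on an aromatic carbon.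

Among the compounds with values here, only one measured step bears on this change: a 1.1-fold higher number from compound 1 to compound 2 (0.03 log units; within the scatter), which exchanged one group for another on the same aromatic carbon of the sulfonyl-bearing ring and left the number essentially unchanged. Within the data shown here, the step from compound 3 to compound 4 touches that same position, and no measured step at this position has moved the number beyond the scatter. The expectation for this assay is therefore a step of a 1.1-fold higher number from compound 3 to compound 4 (0.06 log units; within the scatter), too small to count as a real difference in either direction. Compound 4 is estimated at 4000 nM, with a likely range from 1800 nM to 9000 nM.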

Compound 4, half-maximal inhibitory concentration: 2600 nM
Estimate against measurement, compound 4: 1.5-fold (0.19 log units) above; the range from low to high includes it.
By their numbers in this assay, from the lowest: compounds 4, 3, 1 and 2 (each within the scatter of the next).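

In this assay, within the data shown here, the exchange of methyl for cyano on the sulfonyl-bearing ring gives a 1.3-fold lower number from compound 3 to compound 4 (0.13 log units; within the scatter) and stays within the scatter, as did the only earlier exchange at this carbon, a 1.1-fold higher number from compound 1 to compound 2 (0.03 log units; within the scatter) on the slightly different core of compound 1. A flat result at this carbon is therefore no longer tied to one pair of groups or to one core, and it now also covers a change that brings in a triple bond, one more heavy atom and a hydrogen-bond acceptor. Nothing shown here gives a measured property of these groups, so the data offer no explanation for the absence of a clear shift.

As far as these compounds go, all four groups seen at this carbon are uncharged, so it remains open whether an amine or a carboxylic acid there would leave the number just as flat or move it beyond the scatter. From the compounds shown here alone, it is also open whether a small group such as a hydroxyl would behave the same way on another carbon of this ring, since every exchange shown sits para to a large group.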